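This account rests on a few compounds, and the source may have more. Where it says the series, first, only, none or still open, it means among the compounds named here.

Measured compounds:
Compound 1, `CCCCCCCCNC[C@@H]1OC[C@H](N)[C@@H]1O`: 96600 nM in a functional assay on MCF7 cells (Homo sapiens) for antiproliferative activity, read by MTT assay, with a stated time of 72 h; on this read-out higher numbers stand for weaker inhibition and lower numbers for stronger inhibition
Compound 2, `CCCCCCCCCCCCNC[C@@H]1OC[C@H](N)[C@@H]1O`: 1800 nM
Compound 3, `CCCCCCCNC[C@@H]1OC[C@H](N)[C@H]1O`: only a limit, > 128000 nM

Compound 1 and compound 2 share one core and differ in one place, (butyl in place of hydrogen on a saturated chain carbon, eight bonds along the chain from an amine nitrogen). That change gave a 54-fold lower number from compound 1 to compound 2 (1.73 log units; beyond the scatter), a large gain in potency. For compound 3 this assay reports only a limit, > 128000 nM, not a number. The difference between the core of compound 3 and the core of compound 1 is not broken down here.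

Compound 4, `CCCCCCCCCCCNC[C@@H]1OC[C@H](N)[C@H]1O`, has not yet been measured. It differs from compound 3 by butyl in place of hydrogen on a saturated chain carbon, seven bonds along the chain from an amine nitrogen. Among the compounds with values here, this is the same kind of change as the one from compound 1 to compound 2, but not the same: there the butyl enters eight bonds along the chain from an amine nitrogen, here seven bonds along the chain from an amine nitrogen.

If the chain lengthening acts on the core of compound 3 as it did on the core of compound 1, a similar gain is expected. The expectation rests on the step of a 54-fold lower number from compound 1 to compound 2 (1.73 log units; beyond the scatter). It is less firm because the limit of > 128000 nM in this assay, at which 1 of the 3 values shown sits, means the starting point for compound 3 is itself unknown. The step from compound 3 to compound 4 is expected to be an at least 16-fold lower number from compound 3 to compound 4 (1.20 log units; beyond the scatter). Compound 4 is estimated to give 8000 nM, most likely between 2000 nM and 40000 nM.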

Compound 4, half-maximal inhibitory concentration: 13100 nM
Estimate against measurement, compound 4: 1.6-fold (0.21 log units) below; low and high end bracket the measured number.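

In this assay, butyl in place of hydrogen on the chain of compound 3 gave an at least 9.7-fold lower number from compound 3 to compound 4 (0.98 log units; beyond the scatter), so the change lowers the number on this second core as well, and the direction carries over even though the butyl enters seven bonds along the chain from the amine nitrogen here, not eight as on the core of compound 1. This shows a real gain on both cores, but it does not show that the gain has the same size on each, and two cores are too few to support a general rule for the series: the same change on two cores in this assay, a 54-fold lower number (1.73 log units; beyond the scatter) from compound 1 to compound 2 and an at least 9.7-fold lower number (0.98 log units; beyond the scatter) from compound 3 to compound 4; the limit leaves it open whether they differ The true size of the second step remains unknown, and the printed figure is only its lower bound, set by compound 3: the limit of > 128000 nM in this assay, at which 1 of the 4 values shown sits.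

The compounds shown leave open how a still longer chain would behave on either core, and whether the gain would hold if a chain carrying an amine or a carboxylic acid entered in place of butyl. They also leave open how much the core alone matters, as a direct reading of that would need two compounds that differ only in the core.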